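The source may report more compounds than this note shows. Statements on the series, on what has been measured and on what is new or still open speak of the compounds shown alone.

Compound 1 `C[Se]/C(=N\C(=O)c1cccs1)NC(=O)c1cccs1` in a functional assay on K562 cells (Homo sapiens) for cytotoxicity, read by MTT assay, with a stated time of 72 h (a higher number here means a weaker inhibitor of growth, a lower number a stronger inhibitor of growth), gives > 100000 nM, which is a limit of the assay rather than a number.
Compound 2 `C[Se]/C(=N\C(=O)c1ccco1)NC(=O)c1ccco1` in this assay gives > 100000 nM, again a limit of the assay.
Compound 3 `CS/C(=N\C(=O)c1ccco1)NC(=O)c1ccco1` in this assay gives > 100000 nM, also a limit of the assay.

Compound 3 therefore stands at the limit of this assay, exactly where the other two measured compounds stand; the summary the limit of > 100000 nM in this assay, at which 3 of the 3 values shown sit, says the same. For the measured compounds named here, the only measured step between two compounds that differ in one place is a step that the two limits leave unreadable from compound 2 to compound 3. Both of its ends are limits, so its size cannot be read, and it gives no sense of how much a change at this position moves the read-out.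

Compound 4 `O=C(/N=C(/NC(=O)c1ccco1)[Se]Cc1ccccc1)c1ccco1` differs from compound 3 in one place: a group of 8 heavy atoms (7 carbon, 1 selenium; one six-membered aromatic ring of carbon only) in place of a group of 2 heavy atoms (1 carbon, 1 sulfur; no ring), on a carbon with a double bond to nitrogen. Going by the values given here, no measured step covers a change of this kind, so the expectation for compound 4 rests only on the fact that, as the limit of > 100000 nM in this assay, at which 3 of the 3 values shown sit, records, every value in this assay so far sits at the limit. Compound 4 is therefore expected to give roughly 80000 nM, with a range from 15000 nM to 300000 nM, and most likely it will again be reported only as a limit. This estimate means an expected step of an at least 1.2-fold lower number from compound 3 to compound 4 (0.09 log units; that floor lies within the scatter), which nothing measured can confirm or contradict.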

Compound 4, concentration for total growth inhibition: 44200 nM
Compound 4: the middle estimate sits 1.8-fold (0.26 log units) above what was measured; measured number inside the range.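

Among the compounds shown, compound 4 is the only one with a readable number in this assay, so a change on this carbon with a double bond to nitrogen can now be seen to move the read-out. Phenyl in place of hydrogen on a saturated chain carbon bound to a selenium atom gives an at least 2.2-fold lower number from compound 2 to compound 4 (0.35 log units; beyond the scatter), and this is the cleanest view of the change, with selenium present at both ends; the true size stays open, as only a floor can be read. The swap of methylsulfanyl for the larger selenium group gives an at least 2.2-fold lower number from compound 3 to compound 4 (0.35 log units; beyond the scatter), but it changes sulfur to selenium and adds the aromatic ring together, and the step from compound 2 to compound 3 cannot be read, so the ring-bearing group alone is tied to a readable number, while the other compounds stay at the limit: the limit of > 100000 nM in this assay, at which 3 of the 4 values shown sit.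

Still open, as far as these compounds go, is whether the same ring-bearing group would give a similar number with sulfur in place of selenium. The compounds shown also leave open how a longer chain, or an amine or a carboxylic acid on the phenyl ring, would change the read-out.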